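The compounds below may be only part of what the source reports. "The series", "measured", "known", "first", "only" and "open" are said of these compounds alone.

Measured compounds and their values:
compound 1 `Cn1nc(-c2cccnc2)c2ccccc2c1=O` — 63%
compound 2 `O=c1c2ccccc2c(-c2cccnc2)nn1CC1CCCCC1` — 98%
compound 3 `O=c1c2ccccc2c(-c2cccnc2)nn1Cc1ccccc1` — 97%

In an assay on isolated protein (Oryctolagus cuniculus) with Thromboxane-A synthase (Homo sapiens) as the target, tested at 1 uM (a higher number here means more inhibition at the concentration tested (going by the name of the read-out), a lower number less inhibition), compound 3 stands second of the three measured compounds; its gap to compound 2 lies within the scatter, while the step of a number 34 percentage points higher from compound 1 to compound 3 (beyond the scatter) is large. The unmeasured compound 4 `COCCn1nc(-c2cccnc2)c2ccccc2c1=O` differs from compound 3 by methoxymethyl in place of phenyl on a saturated chain carbon bound to an aromatic nitrogen. Among the compounds with values here, three measured steps bear on this position: a number 35 percentage points higher from compound 1 to compound 2 (beyond the scatter) and a number 34 percentage points higher from compound 1 to compound 3 (beyond the scatter) were both large, whereas a number 1 percentage points lower from compound 2 to compound 3 (within the scatter) was within the scatter. The measured compounds show only hydrogen or a ring at this place, so methoxymethyl lies outside what they cover. The writer expects a downward step, a number 13 percentage points lower from compound 3 to compound 4 (beyond the scatter), smaller than the step from hydrogen. Compound 4 is estimated at 84%, within 66% to 98%.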

Compound 4, a percentage reported as inhibition, at one concentration (the size of the read-out at that concentration, not a potency): 55%
Estimate against measurement, compound 4: 29 percentage points above, and the stated range ends above it.
By their numbers in this assay, from the lowest: compounds 4 and 1 (each within the scatter of the next); then compounds 3 and 2 (each within the scatter of the next).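

In this assay, lengthening the group at this position does not by itself bring the gain seen with compounds 2 and 3: a number 42 percentage points lower from compound 3 to compound 4 (beyond the scatter) and a number 43 percentage points lower from compound 2 to compound 4 (beyond the scatter) are both large, whereas a number 8 percentage points lower from compound 1 to compound 4 (within the scatter) stays small. Among these compounds, the high numbers belong only to the chains carrying a ring, and the 2-methoxyethyl chain does not share them. No evidence at hand explains this difference.

From the compounds shown here alone, it remains open whether the ring or the oxygen decides the outcome. A longer chain of carbon alone, or a chain ending in an amine, could help separate the two.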